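Capping the Phenolic Hydroxy: What Compound 4 May Show

The source may report more compounds than this note shows. Statements on the series, on what has been measured and on what is new or still open speak of the compounds shown alone.

Of the compounds shown here, three have so far been tested in a functional assay on the whole organism for inhibition, with Echinochloa crus-galli as the target; a lower number here means a stronger inhibitor, a higher number a weaker inhibitor. Compound 1 `C=C(C)[C@@H]1Oc2cc(O)c(C(C)=O)cc2[C@H]1OC` gives 323 ug/mL, and compound 2 `COC(C)(C)/C=C/c1cc(C(C)=O)ccc1O[C@@H]1O[C@H](CO)[C@@H](O)[C@H](O)[C@H]1O` gives 231 ug/mL. Compound 3 `CC(=O)c1cc2c(cc1O)OC(C)(C)C=C2` gives 79 ug/mL, the lowest of the three numbers; its gaps to compound 2 and to compound 1 both lie beyond the usual scatter, so compound 3 is the strongest inhibitor among those measured. Compound 4 `COc1cc2c(cc1C(C)=O)C=CC(C)(C)O2` has not yet been measured. It differs from compound 3 in one place: methyl in place of hydrogen on an oxygen on an aromatic ring. For the measured compounds named here, no measured pair shows what this hydroxy-to-methoxy change does, so its direction is uncertain. A moderate weakening is nevertheless expected, estimated as a 1.6-fold higher number from compound 3 to compound 4 (0.22 log units; within the scatter). Compound 4 is thus expected to give 130 ug/mL, within a range from 50 ug/mL to 350 ug/mL.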

Compound 4, half-maximal inhibitory concentration: 6 ug/mL
The estimate for compound 4 lay 22-fold (1.34 log units) above the measured number; measured number outside the range, below it.
By their numbers in this assay, from the lowest: compound 4; then compound 3; then compounds 2 and 1 (each within the scatter of the next).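

In this assay, methyl in place of hydrogen on this oxygen gives a 13-fold lower number from compound 3 to compound 4 (1.12 log units; beyond the scatter), a large step beyond the scatter. The free hydroxy is therefore not required for inhibition in this pair, and capping it strengthens inhibition rather than weakening it. Nothing measured bears on the reason for this step.

The compounds shown leave open whether an ethyl group or a longer chain on this oxygen would go further, or whether an amine in place of the hydroxy would keep the gain. They also leave open whether the same methyl would act alike on the hydroxy of compound 1.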